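The source may report more compounds than this note shows. Statements on the series, on what has been measured and on what is new or still open speak of the compounds shown alone.

The series shares a single core, varied only in the aryl group on the double-bonded chain. Compound 1 `C=CCOc1cc(OC)c(C(=O)/C=C/c2ccc(F)cc2)c(OCC=C)c1` gives 13600 nM in an ADME assay on Vero cells (Chlorocebus sabaeus) for cytotoxicity, read by MTT assay (a higher number here means a weaker inhibitor, a lower number a stronger inhibitor), the higher of the two numbers recorded there; compound 2 `C=CCOc1cc(OC)c(C(=O)/C=C/c2ccncc2)c(OCC=C)c1` gives 2800 nM, and compound 3 `C=CCOc1cc(OC)c(C(=O)/C=C/c2ccc[nH]2)c(OCC=C)c1` gives "not determined" (no result reported). Going by the values given here, the only measured step, a 4.9-fold lower number from compound 1 to compound 2 (0.69 log units; beyond the scatter), swaps the whole aryl group. Compound 4 `C=CCOc1cc(OC)c(C(=O)/C=C/c2ccc(C(F)(F)F)cc2)c(OCC=C)c1` instead keeps the aryl ring and changes a single substituent: trifluoromethyl in place of fluoro on an aromatic carbon. Among the compounds with values here, no measured step bears on this change, so compound 4 is expected to stay close to compound 1, with a step of a 1.1-fold lower number from compound 1 to compound 4 (0.05 log units; within the scatter) that does not exceed the scatter. Compound 4 is therefore estimated at 12000 nM, within a range of 4500 nM to 32000 nM.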

Compound 4, half-maximal inhibitory concentration: 7200 nM
The estimate for compound 4 lay 1.7-fold (0.22 log units) above the measured number; the measured number falls inside the stated range.
By their numbers in this assay, from the lowest: compound 2; then compounds 4 and 1 (each within the scatter of the next).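

In this assay the change from fluoro to trifluoromethyl on the aromatic carbon gives a 1.9-fold lower number from compound 1 to compound 4 (0.28 log units; within the scatter) and so does not separate the two compounds. The pyridin-4-yl of compound 2 also stands apart from this second substituted phenyl, with a 2.6-fold higher number from compound 2 to compound 4 (0.41 log units; beyond the scatter) as the step, so the earlier difference between the aryl groups holds for both phenyl compounds. Nothing available accounts for either step. On these data alone, whether an amine, a carboxylic acid or a longer chain on this aromatic carbon would stay as close to compound 1 remains open, as does the effect of a pyridin-3-yl in place of pyridin-4-yl.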